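This account rests on a few compounds, and the source may have more. Where it says the series, first, only, none or still open, it means among the compounds named here.

Of the compounds shown here, three with a shared core have been measured so far. Compound 1 `O=C(CN1CCC(c2cccc[n+]2[O-])CC1)NC1CCCCC1` gives 294 nM in a functional assay on HEK293 cells for agonist activity at D(4) dopamine receptor (Homo sapiens), read by FLIPR; a higher number here means that more compound is needed for the effect, a lower number that less compound is needed. Compound 2 `O=C(CN1CCC(c2cccc[n+]2[O-])CC1)Nc1cc(Cl)cc(Cl)c1` gives 160 nM in this assay, and compound 3 `Cc1cc(C)cc(C(=O)NCN2CCC(c3cccc[n+]3[O-])CC2)c1` gives 90 nM. Compound 2 therefore stands second highest of the three numbers, but its gap to compound 3 and its gap to compound 1 both lie within the scatter, so none of the three can be set apart from the others. Among the measured compounds shown here, the only measured step that alters the group on the amide nitrogen, a 1.8-fold lower number from compound 1 to compound 2 (0.26 log units; within the scatter), is likewise within the scatter.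

Compound 4 `O=C(CN1CCC(c2cccc[n+]2[O-])CC1)Nc1cccc(Cl)c1` differs from compound 2 by hydrogen in place of chloro on an aromatic carbon. For the measured compounds named here, no measured step removes a single chloro from this ring, so the nearest guide is the small step from compound 1 to compound 2, in which a much larger change at the same part of the molecule barely moved the number. A small step, if any, is therefore expected here, perhaps toward a slightly higher number. Compound 4 is expected to give 250 nM, with a likely range from 100 nM to 700 nM. This estimate corresponds to an expected step of a 1.6-fold higher number from compound 2 to compound 4 (0.19 log units; within the scatter).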

Compound 4, half-maximal effective concentration: 62 nM
Compound 4: middle estimate off by 4.0-fold (0.61 log units), on the high side; measured number outside the range, below it.
By their numbers in this assay, from the lowest: compounds 4, 3, 2 and 1 (each within the scatter of the next, the first and the last beyond it).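

Among the compounds shown here, removing one chloro, so that 3,5-dichlorophenyl becomes 3-chlorophenyl, gives a 2.6-fold lower number from compound 2 to compound 4 (0.41 log units; beyond the scatter) in this assay, the first change at a single place in this set to clear the scatter. With 3-chlorophenyl in place of cyclohexyl on the amide nitrogen, the result is a 4.7-fold lower number from compound 1 to compound 4 (0.68 log units; beyond the scatter), whereas 3,5-dichlorophenyl gave only a 1.8-fold lower number from compound 1 to compound 2 (0.26 log units; within the scatter), so among these compounds an aromatic ring alone does not set the number apart from cyclohexyl, and the chloro pattern on that ring matters. No measurement at hand explains why the second chloro carries this cost.

The compounds shown leave open whether the remaining chloro contributes at all, a question that a plain phenyl ring would answer. They also leave open whether a fluoro, methyl or nitrile group could take its place.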